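The compounds below may be only part of what the source reports. "The series", "measured", "known", "first", "only" and "open" are said of these compounds alone.

Measured compounds in an assay on RPMI-8866 cells for inhibition of integrin alpha-4/beta-1 (Homo sapiens); a higher number here means a weaker inhibitor, a lower number a stronger inhibitor:
compound 1, `CC(C)[C@@H](CC(=O)O)NC(=O)[C@@H]1CCCN1S(=O)(=O)c1cc(Cl)cc(Cl)c1`, 8.9 nM
compound 2, `CCOc1ccc([C@@H](CC(=O)O)NC(=O)[C@@H]2CCCN2S(=O)(=O)c2cc(Cl)cc(Cl)c2)cc1`, 0.27 nM
compound 3, `O=C(O)C[C@@H](NC(=O)[C@@H]1CCCN1S(=O)(=O)c1cc(Cl)cc(Cl)c1)c1ccc(OC2CC2)cc1`, 0.85 nM

Compound 3 stands second of the three numbers in this assay. Its nearest neighbour is compound 2, reached by a 3.1-fold higher number from compound 2 to compound 3 (0.50 log units; beyond the scatter); its furthest is compound 1, from which compound 3 is reached by a 10-fold lower number from compound 1 to compound 3 (1.02 log units; beyond the scatter). Compound 4, `O=C(O)C[C@@H](NC(=O)[C@@H]1CCCN1S(=O)(=O)c1cc(Cl)cc(Cl)c1)c1ccc(OC(F)(F)F)cc1`, is the next step: trifluoromethyl in place of cyclopropyl on an oxygen on an aromatic ring. For the measured compounds named here, no measured step exchanges one group on that aromatic oxygen for a fluorinated one, so the only bearing step is the modest one from compound 2 to compound 3, which shows that what sits on this oxygen shifts the number, but not by as much as the large steps from compound 1 to compound 2 or to compound 3. For compound 4 the expected step is therefore small, a 1.2-fold higher number from compound 3 to compound 4 (0.07 log units; within the scatter), within or only just beyond the scatter. Compound 4 is estimated to give 1 nM in this assay, with a range from 0.3 nM to 3.5 nM.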

Compound 4, half-maximal inhibitory concentration: 2.6 nM
Beside the measured number, compound 4's estimate is 2.6-fold (0.41 log units) below it; low and high end bracket the measured number.
By their numbers in this assay, from the lowest: compound 2; then compound 3; then compound 4; then compound 1.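

In this assay, the group on the oxygen on the aromatic ring matters more than the exchange of ethyl for cyclopropyl alone could show: a 3.1-fold higher number from compound 3 to compound 4 (0.49 log units; beyond the scatter) adds a second step of about the same size, and across the series this amounts to a 9.6-fold higher number from compound 2 to compound 4 (0.98 log units; beyond the scatter). The 4-(trifluoromethoxy)phenyl group still gives a lower number than isopropyl, with a 3.4-fold lower number from compound 1 to compound 4 (0.53 log units; beyond the scatter), but this gain is smaller than a 10-fold lower number from compound 1 to compound 3 (1.02 log units; beyond the scatter), so the gain from the aromatic group depends on what its oxygen carries. No evidence at hand bears on the reason for this order.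

The compounds shown leave open where a methyl group, a difluoromethyl group or a longer chain on that oxygen would fall relative to ethyl, cyclopropyl and trifluoromethyl. They also leave open how an amine in place of the oxygen would compare.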